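Chloro for methyl on the benzyl triazole arm

This account rests on a few compounds, and the source may have more. Where it says the series, first, only, none or still open, it means among the compounds named here.

Compound 3 `COc1ccc([C@@H]2CC(=O)c3c(O)cc(OCc4cn(Cc5ccc(C)cc5)nn4)cc3O2)cc1O` gives the highest number of the three measured in a functional assay on RAW264.7 cells (Mus musculus) for inhibition, read by Griess assay, with stated times of 2 h and 24 h (on this read-out lower numbers stand for stronger inhibition and higher numbers for weaker inhibition), namely 16800 nM, but its nearest neighbour compound 2 `C=CCn1cc(COc2cc(O)c3c(c2)O[C@H](c2ccc(OC)c(O)c2)CC3=O)nn1` gives 13800 nM and compound 1 `COc1ccc([C@@H]2CC(=O)c3c(O)cc(OCc4cn(Cc5ccccc5)nn4)cc3O2)cc1O` gives 11000 nM, and all three sit within the scatter of one another, so no ordering can be read from them. The step of a 1.5-fold higher number from compound 1 to compound 3 (0.18 log units; within the scatter) and the step of a 1.2-fold higher number from compound 2 to compound 3 (0.09 log units; within the scatter) are both small, as is a 1.3-fold higher number from compound 1 to compound 2 (0.10 log units; within the scatter).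

Compound 4 `COc1ccc([C@@H]2CC(=O)c3c(O)cc(OCc4cn(Cc5ccc(Cl)cc5)nn4)cc3O2)cc1O` differs from compound 3 by chloro in place of methyl on an aromatic carbon. The step that bears most directly on it is the exchange of the same substituent group, a 1.5-fold higher number from compound 1 to compound 3 (0.18 log units; within the scatter), which stayed within the scatter; the swap of the whole benzyl arm for allyl, a 1.3-fold higher number from compound 1 to compound 2 (0.10 log units; within the scatter), also stayed within the scatter. Nothing in this small set shows a substituent change on the benzyl ring moving the number beyond the scatter.

For compound 4 the expected step is therefore a 1.1-fold lower number from compound 3 to compound 4 (0.02 log units; within the scatter), no change beyond the scatter. The estimate for compound 4 in this assay is 16000 nM, with a range from 8000 nM to 32000 nM.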

Compound 4, half-maximal inhibitory concentration: 17800 nM
The estimate for compound 4 lay 1.1-fold (0.05 log units) below the measured number, within the range that was stated.
By their numbers in this assay, from the lowest: compounds 1, 2, 3 and 4 (each within the scatter of the next).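

In this assay chloro in place of methyl on the aromatic carbon para to a large group gives a 1.1-fold higher number from compound 3 to compound 4 (0.03 log units; within the scatter) and chloro in place of hydrogen at that carbon gives a 1.6-fold higher number from compound 1 to compound 4 (0.21 log units; within the scatter) so hydrogen, methyl and chloro at this position now span no step beyond the scatter. Replacing vinyl with 4-chlorophenyl on the saturated chain carbon bound to an aromatic nitrogen gives a 1.3-fold higher number from compound 2 to compound 4 (0.11 log units; within the scatter) so this 4-chlorobenzyl arm and the allyl arm of compound 2 also cannot be told apart. No supporting data bear on these results.

Still open, as far as these compounds go, is whether an amine or a carboxylic acid at this position would move the number beyond the scatter. Also open, from the compounds shown here alone, is whether a longer chain in place of the benzyl arm would do so.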